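Aroyl in place of propanoyl on the amide core

The source may hold more compounds than are shown below. What is called first, only, known or untested is meant among the compounds shown, and "the series" means these compounds.

Compound 1, `CCCCCCCCC(=O)N1c2ccccc2CCC1C(=O)Nc1ccccc1C(F)(F)F`: 8330 nM
Compound 2, `CCC(=O)N1c2ccccc2CCC1C(=O)Nc1ccccc1C(F)(F)F`: a limit, > 80000 nM

In a functional assay on ACHN cells (Homo sapiens) for cytotoxicity, read by sulforhodamine B assay, with a stated time of 72 h (on this read-out higher numbers stand for weaker inhibition of growth and lower numbers for stronger inhibition of growth), compound 1 gives 8330 nM. Compound 2 reaches only the assay limit, > 80000 nM. Compound 3, `O=C(Nc1ccccc1C(F)(F)F)C1CCc2ccccc2N1C(=O)c1cccc(Cl)c1`, differs from compound 2 by 3-chlorophenyl in place of ethyl on a carbonyl carbon. Within the data shown here, the only measured step, an at least 9.6-fold higher number from compound 1 to compound 2 (0.98 log units; beyond the scatter), runs the other way: taking hexyl off the chain sends the number to the limit of > 80000 nM in this assay, at which 1 of the 2 values shown sits, so compound 3, which again carries a larger group on that carbonyl carbon, is expected to move back down. Compound 3 is therefore estimated at 15000 nM, within 4000 nM to 80000 nM, an expected at least 5.3-fold lower number from compound 2 to compound 3 (0.72 log units; beyond the scatter).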

Compound 3, concentration for 50% growth inhibition: 526 nM
Compound 3: the middle estimate sits 29-fold (1.46 log units) above what was measured; measured number outside the range, below it.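

Among these compounds, on the carbonyl carbon bound to the ring's amide-type nitrogen, the earlier compounds showed only chains; 3-chlorophenyl in place of ethyl now gives an at least 150-fold lower number from compound 2 to compound 3 (2.18 log units; beyond the scatter). The value of compound 2 is a limit of the assay, not a number: the limit of > 80000 nM in this assay, at which 1 of the 3 values shown sits. 3-Chlorophenyl in place of octyl gives a 16-fold lower number from compound 1 to compound 3 (1.20 log units; beyond the scatter), so in this assay this aromatic ring outdoes the longest chain shown at this position. The compounds shown leave open what the chlorine contributes, and whether plain phenyl, cyclohexyl or a pyridine ring on this carbonyl carbon would hold the lower number.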